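Swapping the ring of compound 1 for a bromophenyl

The source may hold more compounds than are shown below. What is called first, only, known or untested is meant among the compounds shown, and "the series" means these compounds.

The measured compounds:
Compound 1, `COc1ccccc1/C=C/C(=O)OC/C=C/c1cc(OC)c(OC)cc1OC`: 100%
Compound 2, `COc1cc(OC)c(OC)cc1/C=C/COC(=O)/C=C/c1c(OC)ccc(OC)c1OC`: 75%
Compound 3, `COc1cc(OC)c(OC)cc1/C=C/COC(=O)/C=C/c1cc(OC)c(OC)c(OC)c1OC`: 50%

All three were tested in a functional assay on the whole organism (strain Kunming) with Mus musculus as the target, with a stated time of 0.5 h, at a dose of 300 mg/kg by the intraperitoneal route; a higher number here means a weaker effect of the compound at the dose given, a lower number a stronger effect. Compound 1 gives 100%, the highest of the three numbers. Its nearest neighbour is compound 2, which gives 75%, a number beyond the scatter below it; compound 3, with 50%, lies further off still. Compound 1 therefore stands at the weak end of what has been measured.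

Compound 4, `COc1cc(OC)c(OC)cc1/C=C/COC(=O)/C=C/c1ccc(Br)cc1`, has not yet been tested. It is built from compound 1 by one change: 4-bromophenyl in place of 2-methoxyphenyl on a double-bonded chain carbon bound to a double-bonded chain carbon. No pair of measured compounds that differ by a single change is available, so the size of this step cannot be read from a shown example. The shown values of compound 2 and compound 3 only tell that other rings in this place can give lower numbers than compound 1.

Compound 4 is expected to give 85% in this assay, within 60% to 100%, which amounts to an expected step of a number 15 percentage points lower from compound 1 to compound 4 (beyond the scatter) of modest size downward, possibly not beyond the scatter.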

Compound 4, a percentage reported as activity, at one dose (the size of the read-out at that dose, not a potency): 75%
Beside the measured number, compound 4's estimate is 10 percentage points above it; the measured number falls inside the stated range.
By their numbers in this assay, from the lowest: compound 3; then compounds 2 and 4 (each within the scatter of the next); then compound 1.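

Within the data shown here, putting 4-bromophenyl in place of 2-methoxyphenyl on a double-bonded chain carbon bound to a double-bonded chain carbon gives a number 25 percentage points lower from compound 1 to compound 4 (beyond the scatter) in this assay, the first single change at this position whose size can be read. The ring at this position therefore does not need its methoxy oxygen for the effect seen at this dose: the entering 4-bromophenyl has no hydrogen-bond acceptor, and the number still falls. No measurement here explains why the number falls.

As far as these compounds go, this one step removes the methoxy group and adds the bromine together, so the share of each in the change stays unknown. From the compounds shown here alone, a plain phenyl ring would separate the two, and it also remains open how a ring carrying an amine or a carboxylic acid would behave here.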